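Methylsulfanyl Replaces the Carbamate on the Aryl Tail

The compounds below may be only part of what the source reports. "The series", "measured", "known", "first", "only" and "open" are said of these compounds alone.

In an assay for inhibition of Fatty-acid amide hydrolase 1 (Rattus norvegicus) (a higher number here means a weaker inhibitor, a lower number a stronger inhibitor), compound 1 `O=C(O)c1ccc(CCCCCCC(=O)c2ncc(-c3ccccn3)o2)cc1` gives only a limit, > 600 nM. Compound 2 `COc1ccc(CCCCCCC(=O)c2ncc(-c3ccccn3)o2)cc1` gives 6.2 nM, and the step of an at least 96-fold lower number from compound 1 to compound 2 (1.98 log units; beyond the scatter) shows how far a change of the substituent on this aromatic ring can move the number. Compound 3 `CC(C)(C)OC(=O)Nc1cccc(CCCCCCC(=O)c2ncc(-c3ccccn3)o2)c1` gives 2.4 nM, the lowest of the two numbers shown and below that of compound 2. Compound 4 `CSc1cccc(CCCCCCC(=O)c2ncc(-c3ccccn3)o2)c1` differs from compound 3 by methylsulfanyl in place of (tert-butoxycarbonyl)amino on an aromatic carbon. Among the measured compounds shown here, only the step from compound 1 to compound 2 bears on such a change, and it was large; here the entering group is the smaller one, so compound 4 is expected to land near compound 2 and somewhat above compound 3, an estimated 2.1-fold higher number from compound 3 to compound 4 (0.32 log units; beyond the scatter). Compound 4 is therefore estimated at 5 nM, between 1.5 nM and 20 nM.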

Compound 4, inhibition constant: 4.2 nM
Estimate against measurement, compound 4: 1.2-fold (0.08 log units) above; the measured number falls inside the stated range.
By their numbers in this assay, from the lowest: compounds 3, 4 and 2 (each within the scatter of the next, the first and the last beyond it). At a limit, above all of these: compound 1.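

At this position, on an aromatic carbon meta to a large group, methylsulfanyl stands in for (tert-butoxycarbonyl)amino with no change beyond the scatter (the step is a 1.8-fold higher number from compound 3 to compound 4 (0.24 log units; within the scatter)), so in this assay the hydrogen-bond donor of the leaving group is not required for a number in this range. Against the 4-methoxyphenyl tail, the 3-(methylsulfanyl)phenyl tail also stays within the scatter (the step is a 1.5-fold lower number from compound 2 to compound 4 (0.17 log units; within the scatter)), while against the 4-carboxyphenyl tail the change is large (the step is an at least 140-fold lower number from compound 1 to compound 4 (2.15 log units; beyond the scatter)). (That last step is read against a limit and not a number: the limit of > 600 nM in this assay, at which 1 of the 4 values shown sits)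

Open, as far as these compounds go, is whether an amine or a carboxylic acid at this same position would keep the number in this range.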